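Trading Trifluoromethyl for Bromo on a Long Chain

The compounds below may be only part of what the source reports. "The series", "measured", "known", "first", "only" and "open" are said of these compounds alone.

Among the measured compounds shown here, in a physicochemical assay for lipophilicity (on this read-out higher numbers stand for higher lipophilicity and lower numbers for lower lipophilicity), compound 3 `CCCCCCCCCCCCS(=O)(=O)c1ccc(O)c(C(=O)Nc2ccc(C(F)(F)F)cc2)c1` gives 6.2, the highest of the three numbers so far, ahead of compound 2 `CCCCCCCCCCS(=O)(=O)c1ccc(O)c(C(=O)Nc2ccc(Br)cc2)c1` at 5.36 and compound 1 `CCCCS(=O)(=O)c1ccc(O)c(C(=O)Nc2ccc(Br)cc2)c1` at 2.48. Compound 4 `CCCCCCCCCCCCS(=O)(=O)c1ccc(O)c(C(=O)Nc2ccc(Br)cc2)c1` keeps the dodecyl chain of compound 3 and makes a single change: bromo in place of trifluoromethyl on an aromatic carbon. In words, this is bromo in place of trifluoromethyl on an aromatic carbon.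

For the measured compounds named here, no measured step isolates this swap. Going by the values given here, the only measured step, a number 2.88 log units higher from compound 1 to compound 2 (beyond the scatter), is large, but it adds hexyl to the chain, which stays the same here. Compounds 2 and 3 differ in both chain and aromatic group, so their gap cannot separate the two changes. Still, a bromo compound with a decyl chain already reaches the value of compound 2, 5.36, and a dodecyl chain extends that chain only modestly. In this assay, no shift beyond the scatter is therefore expected, and the estimated step is a number 0.05 log units higher from compound 3 to compound 4 (within the scatter). For compound 4, the estimate is 6.25, with an expected range from 5.85 to 6.6.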

Compound 4, distribution coefficient: 6.49
Beside the measured number, compound 4's estimate is 0.24 log units below it; the measured number falls inside the stated range.
By their numbers in this assay, from the lowest: compound 1; then compound 2; then compounds 3 and 4 (each within the scatter of the next).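

In this assay the exchange of trifluoromethyl for bromo on this aromatic carbon gives a number 0.29 log units higher from compound 3 to compound 4 (within the scatter) on the dodecyl chain, so at this position the two groups cannot be told apart on this read-out. With bromo held fixed, going from the decyl to the dodecyl chain gives a number 1.13 log units higher from compound 2 to compound 4 (beyond the scatter) and going from the butyl to the dodecyl chain gives a number 4.01 log units higher from compound 1 to compound 4 (beyond the scatter) so among these compounds only the chain steps lie beyond the scatter. No supporting measurement is available to explain why the exchange registers so little.

As far as these compounds go, whether the same exchange would stay this small on a butyl or decyl chain remains open. So does how a nitrile, a methoxy group or a carboxylic acid at this position would compare, or a chain longer than dodecyl.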